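The compounds below may be only part of what the source reports. "The series", "measured", "known", "first", "only" and "open" are said of these compounds alone.

Compound 1, with the structure `COc1ccc(NC(=O)CNCCCC(=O)Nc2ccccc2N)cc1`, was tested in a functional assay on U-251 cells (Homo sapiens) for inhibition, read by MTT assay, with a stated time of 2 days; on this read-out higher numbers stand for lower toxicity in this test and lower numbers for higher toxicity in this test. In this assay compound 1 gives > 100000 nM, which is a limit of the assay rather than a measured number. Two related compounds share this outcome. Compound 2, `COc1ccc(NC(=O)CNc2ccc(C(=O)Nc3ccccc3N)cc2)cc1`, gives > 100000 nM in this assay, again a limit. Compound 3, `Nc1ccccc1NC(=O)c1ccc(NCC(=O)Nc2ccc([N+](=O)[O-])cc2)cc1`, gives > 100000 nM in this assay, also a limit. Among the measured compounds shown here, all three values sit at the limit of > 100000 nM in this assay, at which 3 of the 3 values shown sit, so the only computed step, a step that the two limits leave unreadable from compound 2 to compound 3, cannot be read in size or direction.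

Compound 4, `Nc1ccccc1NC(=O)CCCNCC(=O)Nc1ccccc1Cl`, has not yet been measured. It differs from compound 1 by 2-chlorophenyl in place of 4-methoxyphenyl on an amide-type nitrogen. For the measured compounds named here, no measured step involves such a change on an amide-type nitrogen, and the one step that exists between the measured compounds is itself unreadable, so no measured step bears on this change with a readable size.

With compound 1 at the limit and nothing pointing another way, compound 4 is expected to stay at or near that limit, an expected step of a number no higher from compound 1 to compound 4 (the limit leaves the size open) that lies within the scatter. The estimate for compound 4 in this assay is therefore 100000 nM, with a range from 30000 nM to 300000 nM.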

Compound 4, concentration lethal to 50% of the cells: > 100000 nM
Compound 4 gave a limit, no number; the forecaster's own chance of this, stated with the estimate: 80%; the middle value sits exactly at the limit.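

Compound 1 and compound 4 both end at the assay's limit, so the change between them cannot be read in size or direction, and all four compounds share the same result: the limit of > 100000 nM in this assay, at which 4 of the 4 values shown sit.

The compounds shown leave open whether 2-chlorophenyl and 4-methoxyphenyl on the amide-type nitrogen differ at all in this test.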